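This account rests on a few compounds, and the source may have more. Where it says the series, first, only, none or still open, it means among the compounds named here.

Three compounds have been measured in an assay for inhibition of high affinity nerve growth factor receptor (Homo sapiens), read by HTRF, with a stated time of 30 min, in the presence of a further agent that is not named here; a lower number here means a stronger inhibitor, a higher number a weaker inhibitor:

compound 1, `Cc1cc(Nc2nc(NCc3ccccc3F)nc3ccccc23)n[nH]1`, giving 110 nM
compound 2, `Cc1cc(Nc2nc(NCc3cc(F)ccc3F)nc3ccccc23)n[nH]1`, giving 7.5 nM
compound 3, `Fc1ccc(CNc2nc(Nc3cc(C4CC4)[nH]n3)c3ccccc3n2)cc1`, giving 40 nM

Compound 1 and compound 2 share a core and differ in one place, (fluoro in place of hydrogen on an aromatic carbon). This change produced a 15-fold lower number from compound 1 to compound 2 (1.17 log units; beyond the scatter) in this assay. Within the data shown here, compound 3 is built on a different core; how it differs from compound 1 is not broken down here, and their numbers show only that compound 3 gives the lower number.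

Compound 4, `Fc1ccc(CNc2nc(Nc3cc(C4CC4)[nH]n3)c3ccccc3n2)c(F)c1`, has not been measured. It differs from compound 3 in one place, (fluoro in place of hydrogen on an aromatic carbon). This is the same kind of change as that from compound 1 to compound 2, but the surroundings differ: in compound 2 the new fluoro sits meta to a large group and para to a fluoro group, whereas in compound 4 it sits ortho to a large group and meta to a fluoro group. Because the earlier change gave a 15-fold lower number from compound 1 to compound 2 (1.17 log units; beyond the scatter), an improvement is expected for compound 4 as well, though a smaller one given the different place; the step is estimated as a 3.1-fold lower number from compound 3 to compound 4 (0.49 log units; beyond the scatter). Compound 4 is therefore expected to give 13 nM in this assay, most likely between 4 nM and 50 nM.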

Compound 4, half-maximal inhibitory concentration: 4.7 nM
Beside the measured number, compound 4's estimate is 2.8-fold (0.44 log units) above it, and the stated range covers the measured number.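

In this assay, replacing hydrogen with fluoro to turn the 4-fluorobenzyl group into 2,4-difluorobenzyl gave an 8.5-fold lower number from compound 3 to compound 4 (0.93 log units; beyond the scatter), so the number fell with this change on the second core as it had on the first. The two steps run in the same direction and cannot be told apart in size: the same change on two cores in this assay, a 15-fold lower number (1.17 log units; beyond the scatter) from compound 1 to compound 2 and an 8.5-fold lower number (0.93 log units; beyond the scatter) from compound 3 to compound 4, 1.7-fold (0.24 log units) apart, within the scatter of two such steps. This shows that the gain carried over between these two pairs, but it rests on those pairs alone, the new fluoro stands at a different place on the ring in each, and it does not show that the gain would carry to any other core or separate the part played by the core from that played by the place.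

The compounds shown leave open whether a chloro or a methoxy group at these places would lower the number as fluoro does. They also leave open whether the step would hold with an ethyl group or a longer chain in place of the methyl or cyclopropyl group.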